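Replacing the amide side chain with an aminochloropyridine

A few compounds are considered here, and "the series" means these few. Any claim that something is new, unique, unknown or untested is made for them only; others in the source may bear on it.

Compound 1 `CC(O)C(=O)Nc1cc(Oc2ccc(Nc3nccc4[nH]cc(-c5ccc(F)cc5)c(=O)c34)cc2F)ccn1` stands highest of the two numbers measured in a functional assay on MKN-45 cells (Homo sapiens) for antiproliferative activity, read by MTT assay, with a stated time of 72 h, tested at 10 uM (on this read-out lower numbers stand for less inhibition and higher numbers for more inhibition at the one concentration tested (going by the name of the read-out)), where compound 1 gives 67.3%. Compound 2 `CCCCC(=O)Nc1cc(Oc2ccc(Nc3nccc4[nH]cc(-c5ccc(F)cc5)c(=O)c34)cc2F)ccn1` gives 62.7% in this assay, and the step of a number 4.6 percentage points lower from compound 1 to compound 2 (within the scatter), butyl in place of 1-hydroxyethyl on a carbonyl carbon, lies within the scatter. Compound 3 `Nc1nccc(Oc2ccc(Nc3nccc4[nH]cc(-c5ccc(F)cc5)c(=O)c34)cc2F)c1Cl` differs from compound 1 by 2-amino-3-chloropyridin-4-yl in place of 2-(((1-hydroxyethyl)carbonyl)amino)pyridin-4-yl on an oxygen on an aromatic ring. Going by the values given here, no measured step touches this part of the structure, so the one step available offers no guidance on direction or size, and no change beyond the scatter is assumed. Compound 3 is therefore expected to give 60%, within a wide range from 35% to 80%. This estimate means a step of a number 7.3 percentage points lower from compound 1 to compound 3 (within the scatter).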

Compound 3, a percentage reported as inhibition, at one concentration (the size of the read-out at that concentration, not a potency): 85.7%
The estimate for compound 3 lay 25.7 percentage points below the measured number, outside the stated range (above it).
By their numbers in this assay, from the lowest: compounds 2 and 1 (each within the scatter of the next); then compound 3.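

In this assay, 2-amino-3-chloropyridin-4-yl in place of 2-(((1-hydroxyethyl)carbonyl)amino)pyridin-4-yl on an oxygen on an aromatic ring gives a number 18.4 percentage points higher from compound 1 to compound 3 (beyond the scatter). This is the first change shown to move the number beyond the scatter, whereas the step between compound 1 and compound 2, confined to the group on the carbonyl carbon, did not. Nothing available bears on what lies behind this rise.

The amino group and the chlorine enter together as the amide leaves, so their shares cannot be told apart. As far as these compounds go, how a bromine or a methyl in place of the chlorine would read also stays open.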